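The source may hold more compounds than are shown below. What is called first, only, known or untested is meant among the compounds shown, and "the series" means these compounds.

The series is assessed in a functional assay on the whole organism with Canis familiaris (Canis lupus familiaris) as the target, at a dose of 8 mg/kg by the oral route; on this read-out lower numbers stand for a weaker effect and higher numbers for a stronger effect at the one dose given. Compound 1 `CCCc1nc2c(OCc3ccccc3)cccn2c1N` gives 0% in this assay. Compound 2 `Cc1cc(OCc2ccccc2)c2nc(C)c(N)n2c1` gives 50% in this assay. Compound 3 `Cc1nc2c(OCc3ccccc3)cccn2c1CN` gives 9% in this assay, a number that stands second of the three: compound 1 sits within the scatter of it, while compound 2 lies well beyond the scatter with the higher number. For the measured compounds named here, no two of these three compounds differ in only one place, so no single step between measured compounds can be read off.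

Compound 4 `CCNc1c(C)nc2c(OCc3ccccc3)cccn12` has not been measured. It differs from compound 3 by ethylamino in place of aminomethyl on an aromatic carbon, a change on the aromatic carbon of the five-membered aromatic ring with two nitrogen in the fused system of two rings. Compound 2, which carries a nitrogen directly on that ring carbon and a methyl on the ring, gives 50%, and this is the nearest guide. The step of a number 16 percentage points higher from compound 3 to compound 4 (beyond the scatter) is expected to be upward and of modest size, near the edge of the scatter. For compound 4 the estimated value is 25%, with a range from 0% to 60%.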

Compound 4, a percentage reported as inhibition, in the whole organism at one dose (the size of the read-out at that dose, not a potency): 68%
Compound 4: middle estimate off by 43 percentage points, on the low side; measured number outside the range, above it.
By their numbers in this assay, from the lowest: compounds 1 and 3 (each within the scatter of the next); then compound 2; then compound 4.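

In this assay, for the compounds shown here, ethylamino in place of aminomethyl on the aromatic carbon of the five-membered aromatic ring gives a number 59 percentage points higher from compound 3 to compound 4 (beyond the scatter) and is the first single change that can be read directly. This position, next to the ring nitrogen and next to the ring atom that bears a methyl group, is therefore sensitive to the group it carries, even though the change leaves the counts of hydrogen-bond donors and acceptors as they were. Nothing given here accounts for the size of this step.

The change alters both the atom attached to the ring, nitrogen for carbon, and the chain beyond it, so the two effects cannot be separated. As far as these compounds go, how methylamino, propylamino or a dimethylamino group would behave at this position remains open.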